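Methoxy in place of dimethylamino: compound 3 awaits measurement

This account rests on a few compounds, and the source may have more. Where it says the series, first, only, none or still open, it means among the compounds named here.

Among the measured compounds shown here, in a functional assay on IMR-32 cells (Homo sapiens) for antiproliferative activity, with a stated time of 72 h (on this read-out higher numbers stand for weaker inhibition and lower numbers for stronger inhibition), compound 2 `CN(C)c1ccc(C(=O)N(CCC(=O)NCc2ccccc2)Cc2ccc(C(=O)NO)cc2)cc1` gives 840 nM as the lowest number so far, while compound 1 `O=C(CCN(Cc1ccc(C(=O)NO)cc1)C(=O)c1ccccc1)NCc1ccccc1` gives 2360 nM as the higher one. Compound 3 `COc1ccc(C(=O)N(CCC(=O)NCc2ccccc2)Cc2ccc(C(=O)NO)cc2)cc1` has not been measured yet. It differs from compound 2 by methoxy in place of dimethylamino on an aromatic carbon, para to a large group (methoxy in place of dimethylamino on an aromatic carbon). For the measured compounds named here, one measured step bears on this change (a 2.8-fold lower number from compound 1 to compound 2 (0.45 log units; beyond the scatter)), with dimethylamino in place of hydrogen on an aromatic carbon. Going by the values given here, that step is modest, and no measured compound carries methoxy. Compound 3 is therefore expected to keep only part of that drop in this assay and to read somewhat higher than compound 2. The expected step is small (a 1.5-fold higher number from compound 2 to compound 3 (0.19 log units; within the scatter)). The estimated value for compound 3 is 1300 nM (expected range 600 nM to 2800 nM).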

Compound 3, half-maximal inhibitory concentration: 1090 nM
Estimate against measurement, compound 3: 1.2-fold (0.08 log units) above; measured number inside the range.
By their numbers in this assay, from the lowest: compounds 2 and 3 (each within the scatter of the next); then compound 1.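

In this assay, methoxy in place of dimethylamino on this aromatic carbon gives a 1.3-fold higher number from compound 2 to compound 3 (0.11 log units; within the scatter), so the two groups cannot be told apart at this position. Methoxy in place of hydrogen gives a 2.2-fold lower number from compound 1 to compound 3 (0.34 log units; beyond the scatter), which shows that the drop from compound 1 is not confined to dimethylamino: a group joined through oxygen rather than nitrogen also reads beyond the scatter. Nothing measured here accounts for either step.

The compounds shown leave open whether a group joined through neither oxygen nor nitrogen, such as methyl or chlorine, would also lower the number at this position. They also leave open how a carboxylic acid or a longer alkoxy chain such as butoxy would read there.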